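A Chloro Substituent Tested on Two Related Cores

The compounds below may be only part of what the source reports. "The series", "measured", "known", "first", "only" and "open" are said of these compounds alone.

Of the compounds shown here, three have so far been measured in a functional assay on DU-145 cells (Homo sapiens) for inhibition, read by MTT assay, with a stated time of 72 h; a higher number here means a weaker inhibitor of growth, a lower number a stronger inhibitor of growth. Compound 1 `COc1ccc(CNC(=O)/C(C#N)=C/c2ccco2)cc1` gives 29000 nM in this assay. Compound 2 `COc1ccc(CNC(=O)/C(C#N)=C/c2ccc(Cl)o2)cc1` gives 12000 nM in this assay. Compound 2 differs from compound 1 by chloro in place of hydrogen on an aromatic carbon, and the measured step is a 2.4-fold lower number from compound 1 to compound 2 (0.38 log units; beyond the scatter). Compound 3 `N#C/C(=C\c1ccccc1)C(=O)NCc1ccc(Cl)c(Cl)c1` gives 71000 nM in this assay, the highest of the three numbers; the difference between the core of compound 3 and the core of compound 1 is not broken down here.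

Compound 4 `N#C/C(=C\c1ccc(Cl)cc1)C(=O)NCc1ccc(Cl)c(Cl)c1` has not yet been measured. It differs from compound 3 by chloro in place of hydrogen on an aromatic carbon. Going by the values given here, this is the same kind of change as the one between compound 1 and compound 2, but not the same change: in compound 2 the chlorine sits on a five-membered aromatic ring with one oxygen, next to the ring oxygen, two ring bonds from the ring atom that bears a large group, whereas in compound 4 it sits on a six-membered aromatic ring of carbon only, para to a large group. Resting on the measured step of a 2.4-fold lower number from compound 1 to compound 2 (0.38 log units; beyond the scatter), the expected step is a 2.0-fold lower number from compound 3 to compound 4 (0.31 log units; beyond the scatter), held a little short of that earlier one, with the place of the change not the same. Compound 4 is thus estimated at 35000 nM in this assay, with a range from 12000 nM to 100000 nM.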

Compound 4, concentration for 50% growth inhibition: 30000 nM
The estimate for compound 4 lay 1.2-fold (0.07 log units) above the measured number; low and high end bracket the measured number.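

In this assay, chloro in place of hydrogen on an aromatic carbon, here on a six-membered aromatic ring of carbon only and para to a large group, gave a 2.4-fold lower number from compound 3 to compound 4 (0.37 log units; beyond the scatter). Set beside the earlier step, the same change kept its size on the second core, even though the ring that carries it and the rest of the molecule both differ between the two pairs: the same change on two cores in this assay, a 2.4-fold lower number (0.38 log units; beyond the scatter) from compound 1 to compound 2 and a 2.4-fold lower number (0.37 log units; beyond the scatter) from compound 3 to compound 4, 1.0-fold (0.01 log units) apart, within the scatter of two such steps. Going by these compounds alone, this agreement rests on only two pairs of compounds, so it supports carrying the chloro step between these two cores but does not show that the step would keep its size on a third core or at another place on these rings, and it gives no reason why the two steps match.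

As far as these compounds go, it remains open whether fluoro, bromo, methyl or methoxy in the same place would give a step of similar size, or whether the match belongs to chloro alone. Also open, from the compounds shown here alone, is how the series would respond to changes elsewhere, such as a carboxylic acid in place of the nitrile or a longer chain between the amide nitrogen and its aromatic ring.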